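The source may report more compounds than this note shows. Statements on the series, on what has been measured and on what is new or still open speak of the compounds shown alone.

Measured compounds:
compound 1 `CC(=O)Nc1cc(-c2c(Nc3cc[nH]n3)nc3ccccn23)nc(C)n1` — 38.3 mL/min/kg
compound 2 `Cc1nc(N)nc(-c2c(Nc3ccn(C)n3)nc3ccc(-c4cncnc4)cn23)n1` — 41.7 mL/min/kg

In an in vivo ADME assay on the whole organism for pharmacokinetics, with Rattus norvegicus as the target, at a dose of 0.5 mg/kg by the intravenous route (on this read-out lower numbers stand for slow clearance and higher numbers for fast clearance), compound 1 gives 38.3 mL/min/kg, the lowest of the two numbers in hand. Compound 2 gives 41.7 mL/min/kg, and the gap between the two lies within the scatter, so no order can be read from it. Compound 3 `CC(=O)Nc1cc(-c2c(Nc3ccn(C)n3)nc3ccccn23)nc(C)n1` has not yet been measured in this assay. Compared with compound 1 it shows (methyl in place of hydrogen on an aromatic nitrogen), in words methyl in place of hydrogen on an aromatic nitrogen. For the measured compounds named here, no measured pair in this set differs by this change alone, so the size of its step is not known from these compounds. The step is expected to be a 1.0-fold lower number from compound 1 to compound 3 (0.00 log units; within the scatter), that is, nothing beyond the scatter in either direction. Compound 3 is accordingly estimated at 38 mL/min/kg, with a range from 22 mL/min/kg to 65 mL/min/kg, resting on the value of compound 1 at 38.3 mL/min/kg.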

Compound 3, clearance: 10 mL/min/kg
Estimate against measurement, compound 3: 3.8-fold (0.58 log units) above; measured number outside the range, below it.
By their numbers in this assay, from the lowest: compound 3; then compounds 1 and 2 (each within the scatter of the next).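

In this assay, methyl in place of hydrogen on the aromatic nitrogen of the 1H-pyrazol-3-yl group gives a 3.8-fold lower number from compound 1 to compound 3 (0.58 log units; beyond the scatter), which shows that this position can move clearance by more than the scatter. Since this is the only difference between the two compounds, the step belongs to this one change, a single added carbon on a nitrogen next to the ring nitrogen, though it rests on this single pair. Nothing available here accounts for the lower number.

On these data alone, whether an ethyl group or a longer chain on the same nitrogen would extend this step, or reverse it, remains open. As far as these compounds go, it is also open whether the same change would give a step of similar size on a core carrying other groups.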